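Methoxy on the fused ring in a chloroquinoline stilbene series

The source may report more compounds than this note shows. Statements on the series, on what has been measured and on what is new or still open speak of the compounds shown alone.

Measured compounds in a functional assay on MCF7 cells (Homo sapiens) for antiproliferative activity, read by sulforhodamine B assay, with a stated time of 72 h; a lower number here means a stronger inhibitor, a higher number a weaker inhibitor:
compound 1 `Fc1ccc(/C=C\c2cc3ccccc3nc2Cl)cc1`, 20300 nM
compound 2 `COc1ccc2nc(Cl)c(/C=C\c3ccc(F)cc3)cc2c1`, 8970 nM
compound 3 `FC(F)(F)c1cccc(/C=C\c2cc3ccccc3nc2Cl)c1`, 3530 nM

Compound 2 differs from compound 1 by methoxy in place of hydrogen on an aromatic carbon; in this assay the step is a 2.3-fold lower number from compound 1 to compound 2 (0.35 log units; beyond the scatter). Compound 3 carries a trifluoromethyl-substituted aryl in place of the fluorophenyl of compound 1; the difference between the two cores is not broken down here, and compound 3 gives the lowest number of the three.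

Compound 4 `COc1ccc2nc(Cl)c(/C=C\c3cccc(C(F)(F)F)c3)cc2c1` is not yet measured. It differs from compound 3 by methoxy in place of hydrogen on an aromatic carbon, the same change as from compound 1 to compound 2. Because the earlier step was a 2.3-fold lower number from compound 1 to compound 2 (0.35 log units; beyond the scatter), a step of about a 2.4-fold lower number from compound 3 to compound 4 (0.37 log units; beyond the scatter) is expected from compound 3 to compound 4 in this assay. Compound 4 is therefore estimated at 1500 nM, with a range from 600 nM to 4000 nM.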

Compound 4, half-maximal inhibitory concentration: 2780 nM
Compound 4: middle estimate off by 1.9-fold (0.27 log units), on the low side, within the range that was stated.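

In this assay methoxy in place of hydrogen on the core of compound 3 gives a 1.3-fold lower number from compound 3 to compound 4 (0.10 log units; within the scatter), so on this core alone the change does not stand out from repeat measurement. Set beside the step on the core of compound 1, the two steps do not separate: the same change on two cores in this assay, a 2.3-fold lower number (0.35 log units; beyond the scatter) from compound 1 to compound 2 and a 1.3-fold lower number (0.10 log units; within the scatter) from compound 3 to compound 4, 1.8-fold (0.25 log units) apart, within the scatter of two such steps. This is compatible with a step carrying over from one core to the other, but two pairs establish neither a constant step nor a dependence on the core.

The compounds shown leave open whether a hydroxyl, an amine or a longer alkoxy chain in place of methoxy would behave alike. From the compounds shown here alone, whether the step holds with other aryl groups also remains open.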